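Swapping Fluoro for Chloro: What Compound 3 Might Show

The compounds below may be only part of what the source reports. "The series", "measured", "known", "first", "only" and "open" are said of these compounds alone.

Compound 1 (`Cc1ncc([N+](=O)[O-])n1CCSc1nnc(-c2ccccc2N)o1`) gives 35100 nM
Compound 2 (`Cc1ncc([N+](=O)[O-])n1CCSc1nnc(-c2ccc(F)cc2)o1`) gives 5300 nM

In a functional assay on SGC-7901 cells (Homo sapiens) for cytotoxicity, read by MTT assay, with a stated time of 48 h (a higher number here means a weaker inhibitor, a lower number a stronger inhibitor), compound 2 holds the lower of the two numbers, which makes it the stronger inhibitor so far. The next candidate is compound 3 (`Cc1ncc([N+](=O)[O-])n1CCSc1nnc(-c2ccc(Cl)cc2)o1`), which has not been measured yet. Its difference from compound 2 is chloro in place of fluoro on an aromatic carbon and in plain terms this is chloro in place of fluoro on an aromatic carbon, para to a large group.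

Among the compounds with values here, only one measured step can serve as a guide, namely a 6.6-fold lower number from compound 1 to compound 2 (0.82 log units; beyond the scatter) and it lies beyond the scatter. That step exchanged 2-aminophenyl for 4-fluorophenyl, so both the group and its place changed, while here the place stays the same. Within the data shown here, it therefore says little about this swap, and no measured pair tests it directly. No direction can be argued from these data, so no shift beyond the scatter is expected. The expected outcome is a 1.1-fold lower number from compound 2 to compound 3 (0.03 log units; within the scatter) in this assay as a working assumption. The estimate for compound 3 is 5000 nM with an expected range of 2000 nM to 13000 nM in this measurement.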

Compound 3, half-maximal inhibitory concentration: 31900 nM
Compound 3: middle estimate off by 6.4-fold (0.80 log units), on the low side; measured number above the stated range.
By their numbers in this assay, from the lowest: compound 2; then compounds 3 and 1 (each within the scatter of the next).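

In this assay, the change from 4-fluorophenyl to 4-chlorophenyl gives a 6.0-fold higher number from compound 2 to compound 3 (0.78 log units; beyond the scatter) in a single step, so this aromatic carbon, para to a large group, is sensitive to which of these two atoms it carries, although one heavy atom replaces another and the counts of hydrogen-bond donors, hydrogen-bond acceptors and charge stay the same. The earlier step from 2-aminophenyl to 4-fluorophenyl could have suggested that any such 4-substituted phenyl would do as well, but the comparison of the chloro compound with the amino compound reads a 1.1-fold lower number from compound 1 to compound 3 (0.04 log units; within the scatter) and lies within the scatter, which leaves compound 2 alone in standing apart from the other two. No independent measurement here offers a reason for the gap between fluoro and chloro.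

The compounds shown leave open what a plain phenyl, a 4-bromophenyl or a 4-methoxyphenyl would give on this same carbon, and so whether fluoro is special or chloro is the exception. They also leave open how 4-aminophenyl would compare, a group that would separate the identity of the amine from its place on the ring.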